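The compounds below may be only part of what the source reports. "The series", "measured", "known", "first", "only" and "open" are said of these compounds alone.

Measured compounds:
compound 1, `CN(C)c1ccc(-c2cccc(N)c2)cc1`: 70%
compound 2, `CN(C)c1ccc(-c2cccc(NC(=O)N3CCOCC3)c2)cc1`: 31%

In an assay on COS-7 cells for inhibition of patatin-like phospholipase domain-containing protein 2 (Mus musculus), tested at 200 uM (on this read-out higher numbers stand for more inhibition at the one concentration tested (going by the name of the read-out) and lower numbers for less inhibition), compound 1 gives 70%, and compound 2 gives 31%. The one measured step, a number 39 percentage points lower from compound 1 to compound 2 (beyond the scatter), places compound 2 as the lower of the two numbers shown; its nearest neighbour, compound 1, stands higher by a step beyond the scatter.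

Compound 3, `CN(C)c1ccc(-c2cccc(NC(=O)C(C)(C)C)c2)cc1`, differs from compound 2 by tert-butyl in place of morpholin-4-yl on a carbonyl carbon. Among the compounds with values here, no measured step bears directly on this change: the only step available, a number 39 percentage points lower from compound 1 to compound 2 (beyond the scatter), concerns the (morpholin-4-yl)carbonyl group entering in place of hydrogen on a nitrogen on an aromatic ring, not an exchange of tert-butyl for morpholin-4-yl on a carbonyl carbon. With nothing to point in either direction, no step beyond the scatter is expected. The estimate for compound 3 in this assay is 35%, with a range from 10% to 60%, meaning an expected step of a number 4 percentage points higher from compound 2 to compound 3 (within the scatter).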

Compound 3, a percentage reported as inhibition, at one concentration (the size of the read-out at that concentration, not a potency): 25%
For compound 3 the middle estimate is 10 percentage points above the measured one, within the range that was stated.
By their numbers in this assay, from the lowest: compounds 3 and 2 (each within the scatter of the next); then compound 1.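

In this assay, a number 6 percentage points lower from compound 2 to compound 3 (within the scatter) with tert-butyl in place of morpholin-4-yl on the carbonyl carbon, so this exchange of a six-membered ring with two hetero atoms for an all-carbon group with no ring leaves no readable difference. The large drop seen earlier also recurs with a second group: a number 45 percentage points lower from compound 1 to compound 3 (beyond the scatter) with (tert-butyl)carbonyl in place of hydrogen on the nitrogen, so compound 2 and compound 3 both stand well under compound 1 while sharing the carbonyl on that nitrogen. Nothing available explains this drop or the lack of a difference between the two groups.

The compounds shown leave open whether the carbonyl itself goes with the lower numbers, which a plain methyl group on that nitrogen, with no carbonyl, would help to separate. They also leave open whether a carboxylic acid or a primary amine at the end of a longer chain on the carbonyl carbon would read differently from tert-butyl and morpholin-4-yl.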